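This account rests on a few compounds, and the source may have more. Where it says the series, first, only, none or still open, it means among the compounds named here.

Measured in a functional assay on HepG2 cells (Homo sapiens) for inhibition, read by MTT assay, with a stated time of 72 h; a lower number here means a stronger inhibitor, a higher number a weaker inhibitor:
- Compound 1 `CC(C)(C)n1cc2c(n1)C(=O)CC1(CCN(C(=O)c3cc(-c4ccc(Cl)cc4)nc4ccccc34)CC1)O2`: 630 nM
- Compound 2 `CC(C)(C)n1cc2c(n1)C(=O)CC1(CCN(C(=O)c3cc(-c4ccc(F)cc4)nc4ccccc34)CC1)O2`: 2930 nM
- Compound 3 `COc1ccc(-c2cc(C(=O)N3CCC4(CC3)CC(=O)c3nn(C(C)(C)C)cc3O4)c3ccccc3n2)cc1`: 2780 nM

These three compounds share one core and differ in a single group on an aromatic carbon: chloro in compound 1, fluoro in compound 2 and methoxy in compound 3. Compound 1 is the strongest inhibitor of the three. Compound 3 gives a clearly higher number, shown by the step of a 4.4-fold higher number from compound 1 to compound 3 (0.64 log units; beyond the scatter), and it stands level with compound 2, as the step of a 1.1-fold lower number from compound 2 to compound 3 (0.02 log units; within the scatter) shows.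

Compound 4 `COc1ccc(-c2cc(C(=O)N3CCC4(CC3)CC(=O)c3nn(C(C)(C)C)cc3O4)c3ccccc3n2)cc1OC` keeps all of compound 3 and gains one group: methoxy in place of hydrogen on an aromatic carbon. In words, this is methoxy in place of hydrogen on an aromatic carbon, turning 4-methoxyphenyl into 3,4-dimethoxyphenyl.

Within the data shown here, no measured step adds a second group, so the data offer only indirect guidance. The step of a 4.7-fold higher number from compound 1 to compound 2 (0.67 log units; beyond the scatter) and the step from chloro to methoxy were modest, and both were swaps of one group for another. Compound 3 already carries a methoxy group, and the swap that produced it from compound 2 changed nothing beyond the scatter. A step beyond the scatter is therefore not expected in this assay, and no direction can be favoured with confidence. The expected step is a 1.1-fold lower number from compound 3 to compound 4 (0.05 log units; within the scatter). For compound 4 the estimated value is 2500 nM, with an expected range from 850 nM to 6500 nM.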

Compound 4, half-maximal inhibitory concentration: 1560 nM
Estimate against measurement, compound 4: 1.6-fold (0.20 log units) above, within the range that was stated.
By their numbers in this assay, from the lowest: compound 1; then compounds 4, 3 and 2 (each within the scatter of the next).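

Adding a second methoxy group to compound 3, on the aromatic carbon ortho to the first one, leaves the number in this assay within the usual scatter (a 1.8-fold lower number from compound 3 to compound 4 (0.25 log units; within the scatter)). Among these compounds, this is the first step here that adds a group instead of swapping one, and it shows that 3,4-dimethoxyphenyl also stands within the scatter of 4-fluorophenyl (a 1.9-fold lower number from compound 2 to compound 4 (0.27 log units; within the scatter)), while 4-chlorophenyl still gives the stronger inhibitor by a modest margin beyond the scatter (a 2.5-fold higher number from compound 1 to compound 4 (0.39 log units; beyond the scatter)). Nothing measured in this set explains why these groups give the numbers they do.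

The compounds shown leave open whether a different kind of group on this ring, such as an amine, a carboxylic acid or a longer alkoxy chain, would shift the number beyond the scatter in either direction. Among the compounds shown here, they also leave open how a chloro group would behave at the place of the added methoxy group, and whether it could give a stronger inhibitor than the single chloro group of compound 1.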